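Replacing a Chlorophenoxy Ether with a Chloroanilino Link

The source may hold more compounds than are shown below. What is called first, only, known or untested is meant among the compounds shown, and "the series" means these compounds.

Compound 1, `O=C(COc1ccccc1Cl)NNC(=S)NCc1ccc(-c2ccccc2)cc1`: 1900 nM
Compound 2, `O=C(COc1cccc(Cl)c1)NNC(=S)NCc1ccc(-c2ccccc2)cc1`: 2100 nM
Compound 3, `O=C(COc1ccc(Cl)cc1Cl)NNC(=S)NCc1ccc(-c2ccccc2)cc1`: 1200 nM

These three compounds share one core and differ only in the chlorine pattern on the phenoxy ring. In an assay on isolated protein for inhibition of A disintegrin and metalloproteinase with thrombospondin motifs 5 (Homo sapiens), read by spectrophotometry, with stated times of 10 min and 3 h (a lower number here means a stronger inhibitor, a higher number a weaker inhibitor), compound 1 gives 1900 nM, the second highest of the three numbers; its nearest neighbour is a 1.1-fold higher number from compound 1 to compound 2 (0.04 log units; within the scatter) and its furthest a 1.6-fold lower number from compound 1 to compound 3 (0.20 log units; within the scatter). Compound 4, `O=C(CNc1ccc(Cl)cc1)NNC(=S)NCc1ccc(-c2ccccc2)cc1`, differs from compound 1 by (4-chlorophenyl)amino in place of 2-chlorophenoxy on a saturated chain carbon bound to a carbonyl carbon. Among the measured compounds shown here, no measured step exchanges the ether oxygen for a nitrogen; the steps at hand only move or add a chlorine, a 1.8-fold lower number from compound 2 to compound 3 (0.24 log units; within the scatter) among them, and every one stays within the scatter. Compound 4 is therefore expected to show no step beyond the scatter, no change at the digits printed from compound 1 to compound 4 (within the scatter). Compound 4 is estimated at 1900 nM in this assay, with a range from 700 nM to 5500 nM.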

Compound 4, half-maximal inhibitory concentration: 6300 nM
The estimate for compound 4 lay 3.3-fold (0.52 log units) below the measured number; measured number outside the range, above it.
By their numbers in this assay, from the lowest: compounds 3, 1 and 2 (each within the scatter of the next); then compound 4.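

Moving or adding chlorine on the phenoxy ring had stayed within the scatter, but (4-chlorophenyl)amino gives the first steps beyond it in this assay: a 3.3-fold higher number from compound 1 to compound 4 (0.52 log units; beyond the scatter) and a 3.0-fold higher number from compound 2 to compound 4 (0.48 log units; beyond the scatter) and a 5.3-fold higher number from compound 3 to compound 4 (0.72 log units; beyond the scatter) in turn. This place, on a saturated chain carbon bound to a carbonyl carbon, therefore responds to a change of the group it carries, one that also adds a hydrogen-bond donor. Nothing measured here accounts for the step. Compound 4 differs in both its linking atom and its chlorine placement, so the compounds shown do not separate the two. As far as these compounds go, how a thioether or a methylene link would behave here also remains open.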